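The source may report more compounds than this note shows. Statements on the series, on what has been measured and on what is new or still open speak of the compounds shown alone.

Measured so far:
- compound 1 `Nc1ccccc1NC(=O)c1ccc(CSC(=S)N2CCN(C(c3ccccc3)c3ccccc3)CC2)cc1`: 9.9%
- compound 2 `COc1ccc(N2CCN(C(=S)SCc3ccc(C(=O)Nc4ccccc4N)cc3)CC2)cc1`: 22.9%
- compound 3 `CC1CCCCN1C(=S)SCc1ccc(C(=O)Nc2ccccc2N)cc1`: 86.9%

In a functional assay on MGC-803 cells (Homo sapiens) for antiproliferative activity, read by CCK-8 assay, with a stated time of 72 h, tested at 8 uM (on this read-out lower numbers stand for a weaker effect and higher numbers for a stronger effect at the one concentration tested), compound 2 gives 22.9% and stands second highest of the three numbers. Its nearest neighbour is compound 1, which in this assay gives 9.9%, a number lower than that of compound 2 and beyond the scatter. Furthest away is compound 3, which in this assay gives 86.9%, far above compound 2 and also beyond the scatter.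

The unmeasured compound 4 `Nc1ccccc1NC(=O)c1ccc(CSC(=S)N2CCN(C3CCCCC3)CC2)cc1` differs from compound 2 in one place: cyclohexyl in place of 4-methoxyphenyl on an amine nitrogen in a ring. No single-point step between measured compounds is available, so the size of this step is not shown by any pair. For the measured compounds named here, compound 3, the one compound without an aromatic group on the ring nitrogen, carries the highest number, which points toward a rise when the 4-methoxyphenyl leaves; compound 1, though, also lacks a cyclohexyl and sits lowest, so the direction rests on one compound only. A rise beyond the scatter is expected in this assay, of moderate size rather than the full distance to compound 3.

For compound 4 the estimate in this assay is 42%, with a range from 15% to 75%. The expected step is a number 19.1 percentage points higher from compound 2 to compound 4 (beyond the scatter).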

Compound 4, a percentage reported as inhibition, at one concentration (the size of the read-out at that concentration, not a potency): 75.3%
The estimate for compound 4 lay 33.3 percentage points below the measured number; measured number above the stated range.
By their numbers in this assay, from the lowest: compound 1; then compound 2; then compound 4; then compound 3.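

In this assay the group on this amine nitrogen in a ring now has a step of its own: with cyclohexyl in place of 4-methoxyphenyl, the read-out shows a number 52.4 percentage points higher from compound 2 to compound 4 (beyond the scatter) and this large change lies beyond the scatter. For the compounds shown here, the earlier compounds offered no pair differing in one place, so this is the first direct sign that the read-out responds strongly to a change at this position. No measurement at hand accounts for the size of this step.

The pair does not separate the loss of the methoxy group from the change of an aromatic ring to a non-aromatic one, and an unsubstituted phenyl on this nitrogen would bear on that. Going by these compounds, whether a cyclopentyl ring or an open butyl chain would read closer to compound 2 or to compound 4 also remains open.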